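Bromo in place of nitro on the shared core

The compounds below may be only part of what the source reports. "The series", "measured", "known", "first", "only" and "open" are said of these compounds alone.

Compound 1 `O=C(N/N=C/c1ccncc1)c1cc2cc(Br)ccc2oc1=O` gives 6340 nM
Compound 2 `O=C(N/N=C/c1cccnc1)c1cc2cc([N+](=O)[O-])ccc2oc1=O` gives 17100 nM

In a functional assay on CCRF-CEM cells (Homo sapiens) for antiproliferative activity, read by fluorescence and resazurin assay, with a stated time of 48 h (a lower number here means a stronger inhibitor, a higher number a weaker inhibitor), compound 2 stands at 17100 nM as the higher of the two numbers, a gap beyond the scatter. Compound 3 `O=C(N/N=C/c1cccnc1)c1cc2cc(Br)ccc2oc1=O` has bromo in place of nitro on an aromatic carbon, and its difference from compound 2 counts as bromo in place of nitro on an aromatic carbon in full. Compound 1 at 6340 nM also carries bromo, yet it differs from compound 2 in more than one place and is only a rough guide. A modest fall in the number, beyond the scatter, is expected, with the estimated step of a 2.3-fold lower number from compound 2 to compound 3 (0.36 log units; beyond the scatter) as the working figure. For compound 3 the expected value is 7500 nM within an estimated range of 3000 nM to 16000 nM for now.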

Compound 3, half-maximal inhibitory concentration: 3710 nM
Estimate against measurement, compound 3: 2.0-fold (0.31 log units) above; measured number inside the range.
By their numbers in this assay, from the lowest: compounds 3 and 1 (each within the scatter of the next); then compound 2.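

In this assay, going by these compounds alone, bromo in place of nitro on an aromatic carbon of the shared core gives a 4.6-fold lower number from compound 2 to compound 3 (0.66 log units; beyond the scatter) with pyridin-3-yl held constant, the first single-change reading at this position. With bromo on the core, pyridin-3-yl in place of pyridin-4-yl gives a 1.7-fold lower number from compound 1 to compound 3 (0.23 log units; within the scatter) and so does not separate the two pyridines. No measured evidence accounts for either step. On these data alone, whether chloro, methoxy or an amine at this position would track bromo or nitro remains open. As far as these compounds go, whether the two pyridines also stay inseparable with nitro on the core is equally open.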